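Chloro to methoxy at the outer aromatic carbon

The source may hold more compounds than are shown below. What is called first, only, known or untested is meant among the compounds shown, and "the series" means these compounds.

Compound 1 `CC(=O)N1N=C(c2ccc(C)cc2)CC1c1ccc(C(=O)OC(C)Cn2c([N+](=O)[O-])cnc2C)cc1` and compound 2 `CC(=O)N1N=C(c2ccc(Cl)cc2)CC1c1ccc(C(=O)OC(C)Cn2c([N+](=O)[O-])cnc2C)cc1` share one core and differ at a single aromatic carbon. In a functional assay on HepG2 cells (Homo sapiens) for antiproliferative activity, read by MTT assay, with a stated time of 12 h (on this read-out higher numbers stand for weaker inhibition and lower numbers for stronger inhibition), compound 1 gives 58100 nM and compound 2 gives 12200 nM; the step of a 4.8-fold lower number from compound 1 to compound 2 (0.68 log units; beyond the scatter) is the only one measured, so compound 2 stands at the lower number of the two. Compound 3 `COc1ccc(C2=NN(C(C)=O)C(c3ccc(C(=O)OC(C)Cn4c([N+](=O)[O-])cnc4C)cc3)C2)cc1` carries methoxy in place of chloro on an aromatic carbon. Among the measured compounds shown here, no measured step involves a methoxy; the step of a 4.8-fold lower number from compound 1 to compound 2 (0.68 log units; beyond the scatter) shows only that this carbon answers to exchange, so a step of similar order in either direction is possible. Compound 3 is expected at 30000 nM (range 8000 nM to 100000 nM). The expected step is a 2.5-fold higher number from compound 2 to compound 3 (0.39 log units; beyond the scatter).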

Compound 3, half-maximal inhibitory concentration: 25200 nM
For compound 3 the middle estimate is 1.2-fold (0.08 log units) above the measured one; the measured number falls inside the stated range.
By their numbers in this assay, from the lowest: compound 2; then compound 3; then compound 1.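

In this assay the change from 4-chlorophenyl to 4-methoxyphenyl gives a 2.1-fold higher number from compound 2 to compound 3 (0.32 log units; beyond the scatter) while methoxy in place of methyl gives a 2.3-fold lower number from compound 1 to compound 3 (0.36 log units; beyond the scatter) on the same aromatic carbon. The methoxy compound therefore lies between the chloro and methyl compounds, and each of the modest steps lies beyond the scatter. Nothing available accounts for this order.

Going by these compounds, whether an amine, a carboxylic acid or a fluoro group at this carbon would fall outside this span remains open. Also open, on these data alone, is whether the order of the three groups holds when the rest of the shared core is changed.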